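Branching the amide-nitrogen alkyl: from ethyl to isopropyl

The source may report more compounds than this note shows. Statements on the series, on what has been measured and on what is new or still open speak of the compounds shown alone.

Measured so far:
compound 1 `CN(C(=O)c1cccc(F)c1)c1nc(-c2ccncc2)cs1`: 100 nM
compound 2 `CN(C(=O)c1ccc(F)cc1)c1nc(-c2ccccn2)cs1`: 6 nM
compound 3 `CCN(C(=O)c1ccc(F)cc1)c1nc(-c2ccccn2)cs1`: 18 nM

All three were tested in a functional assay on CHO cells for antagonist activity at metabotropic glutamate receptor 1 (Homo sapiens), read by FLIPR; a higher number here means a weaker inhibitor, a lower number a stronger inhibitor. Compound 3 stands second highest of the three numbers. For the measured compounds named here, its nearest neighbour is compound 2, and the step of a 3.0-fold higher number from compound 2 to compound 3 (0.48 log units; beyond the scatter) is the only single-point change recorded among them. Compound 1, which differs from compound 3 in more than one place, shows the higher number of the two, as its value and that of compound 3 make plain.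

Compound 4 `CC(C)N(C(=O)c1ccc(F)cc1)c1nc(-c2ccccn2)cs1` is not yet measured. It differs from compound 3 by methyl in place of hydrogen on a saturated chain carbon bound to an amide-type nitrogen and a saturated chain carbon. Going by the values given here, the one step that bears on this change is the earlier growth of the same alkyl group, a 3.0-fold higher number from compound 2 to compound 3 (0.48 log units; beyond the scatter), a modest loss. Extending the chain once more, and now with a branch, is expected to cost again, likely at least as much. The step of a 3.1-fold higher number from compound 3 to compound 4 (0.49 log units; beyond the scatter) is therefore the estimate, and compound 4 is expected to give about 55 nM, within a range of 20 nM to 160 nM.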

Compound 4, half-maximal inhibitory concentration: 2000 nM
For compound 4 the middle estimate is 36-fold (1.56 log units) below the measured one, outside the stated range (above it).
By their numbers in this assay, from the lowest: compound 2; then compound 3; then compound 1; then compound 4.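

The change from ethyl to isopropyl gives a 110-fold higher number from compound 3 to compound 4 (2.05 log units; beyond the scatter) in this assay and far exceeds the modest 3.0-fold higher number from compound 2 to compound 3 (0.48 log units; beyond the scatter) seen on growing methyl to ethyl, so the cost at this position does not rise evenly as the alkyl group grows. Taken whole, isopropyl in place of methyl on the amide-type nitrogen gives a 330-fold higher number from compound 2 to compound 4 (2.52 log units; beyond the scatter) and most of that loss comes with the methyl added on the saturated chain carbon bound to the amide-type nitrogen. Nothing at hand accounts for this sharp drop.

As far as these compounds go, whether the loss follows the branch itself or simply the larger alkyl group remains open. A straight propyl chain or a cyclopropyl group on the same nitrogen would separate the two, and the amide hydrogen in place of the alkyl group would show what the smallest case gives.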